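Trifluoromethyl to chloro on a urea-bearing pyrazole series

A few compounds are considered here, and "the series" means these few. Any claim that something is new, unique, unknown or untested is made for them only; others in the source may bear on it.

Two compounds share one core and differ in the group carried on the carbonyl carbon. Compound 1 `COc1cc(Cl)cc(-c2nn(-c3cccc(NC(=O)c4ccc(Cl)c(Cl)c4)c3)cc2-c2ccncc2)c1` holds a 3,4-dichlorophenyl there; in a functional assay on Malme-3M cells (Homo sapiens) for inhibition, read by sulforhodamine B assay, with a stated time of 48 h, tested at 10 uM (on this read-out lower numbers stand for a stronger effect and higher numbers for a weaker effect at the one concentration tested), compound 1 gives 96.4%. Compound 2 `COc1cc(Cl)cc(-c2nn(-c3cccc(NC(=O)Nc4ccc(Cl)c(C(F)(F)F)c4)c3)cc2-c2ccncc2)c1` holds a (4-chloro-3-(trifluoromethyl)phenyl)amino instead, and in this assay compound 2 gives -19.8%, the lowest of the two numbers, with a number 116.2 percentage points lower from compound 1 to compound 2 (beyond the scatter).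

For the measured compounds named here, compound 3 `COc1cc(Cl)cc(-c2nn(-c3cccc(NC(=O)Nc4ccc(Cl)c(Cl)c4)c3)cc2-c2ccncc2)c1` is the next step from compound 2. chloro in place of trifluoromethyl on an aromatic carbon The only measured step, that from compound 1 to compound 2, changed two things at once, the linking group and the aryl substitution, so no measured step isolates the change from compound 2 to compound 3. The large drop seen in that step may rest on either part. The trifluoromethyl-to-chloro exchange is therefore expected to leave the effect in this assay broadly where compound 2 stands, with an estimated a number 29.8 percentage points higher from compound 2 to compound 3 (beyond the scatter) that could reach beyond the scatter in either direction. Compound 3 is estimated at 10%, between -25% and 60%.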

Compound 3, a percentage reported as activity, at one concentration (the size of the read-out at that concentration, not a potency): -19.8%
Estimate against measurement, compound 3: 29.8 percentage points above; measured number inside the range.
By their numbers in this assay, from the lowest: compounds 2 and 3 (each within the scatter of the next); then compound 1.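

With the link on the carbonyl carbon held constant, the exchange of trifluoromethyl for chloro on this aromatic carbon, ortho to a chloro group, gives no change at the digits printed from compound 2 to compound 3 (within the scatter) in this assay, so in this pair the read-out does not separate the two groups. Compound 3 also differs from compound 1 in one place only, with (3,4-dichlorophenyl)amino in place of 3,4-dichlorophenyl on a carbonyl carbon, and that change gives a number 116.2 percentage points lower from compound 1 to compound 3 (beyond the scatter). The earlier pair altered the linking group and the aryl substitution together, and it could not assign its step to one change. Nothing available explains either the large step or the absence of a change at the aromatic carbon.

As far as these compounds go, whether the same tolerance extends to other groups on this aromatic carbon, such as a nitrile, an amine or a carboxylic acid, remains open. From the compounds shown here alone, it is also open whether the large step is specific to the amino link, or whether a methylene or an ether oxygen in its place on the carbonyl carbon would give a similar read-out.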